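A few compounds are considered here, and "the series" means these few. Any claim that something is new, unique, unknown or untested is made for them only; others in the source may bear on it.

Measured compounds in a functional assay on B16-F10 cells (Mus musculus) for antiproliferative activity, read by MTT assay, with a stated time of 48 h; on this read-out lower numbers stand for stronger inhibition and higher numbers for weaker inhibition:

Compound 1 `COc1ccc(-c2nn(-c3ccccc3)cc2CNc2ccc(Br)cc2)cc1` gives 8060 nM.
Compound 2 `Brc1ccc(NCc2cn(-c3ccccc3)nc2-c2ccc(Br)cc2)cc1` gives 5270 nM.
Compound 3 `COc1ccc(-c2nn(-c3ccccc3)cc2CNc2ccc(Cl)cc2)cc1` gives 7180 nM.

All three numbers sit close together. Compound 1 and compound 2 differ by bromo in place of methoxy on an aromatic carbon, and the step in this assay is a 1.5-fold lower number from compound 1 to compound 2 (0.18 log units; within the scatter). Compound 1 and compound 3 differ by chloro in place of bromo on an aromatic carbon, with a step of a 1.1-fold lower number from compound 1 to compound 3 (0.05 log units; within the scatter) in this assay. Neither step passes beyond the usual scatter, so no order among compound 1, compound 2 and compound 3 can be read from these numbers.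

Compound 4 `Clc1ccc(NCc2cn(-c3ccccc3)nc2-c2ccc(Br)cc2)cc1` is not yet measured. It differs from compound 3 by bromo in place of methoxy on an aromatic carbon. Within the data shown here, this is the same change as the one from compound 1 to compound 2, made on a core that differs from the core of compound 1 by chloro in place of bromo on an aromatic carbon; the two place descriptions read identically. Since the step from compound 1 to compound 2 was a 1.5-fold lower number from compound 1 to compound 2 (0.18 log units; within the scatter), a step of about the same size is expected here, a 1.5-fold lower number from compound 3 to compound 4 (0.17 log units; within the scatter), though that pair of compounds alone is a thin basis. The value of compound 4 in this assay is estimated at 4800 nM, expected to lie between 2500 nM and 9500 nM.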

Compound 4, half-maximal inhibitory concentration: 4290 nM
For compound 4 the middle estimate is 1.1-fold (0.05 log units) above the measured one; low and high end bracket the measured number.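

In this assay, bromo in place of methoxy gives a 1.7-fold lower number from compound 3 to compound 4 (0.22 log units; within the scatter), and this step agrees with the earlier one on the other core: the same change on two cores in this assay, a 1.5-fold lower number (0.18 log units; within the scatter) from compound 1 to compound 2 and a 1.7-fold lower number (0.22 log units; within the scatter) from compound 3 to compound 4, 1.1-fold (0.04 log units) apart, within the scatter of two such steps

Chloro in place of bromo gives a 1.2-fold lower number from compound 2 to compound 4 (0.09 log units; within the scatter), and the same holds for this change: the same change on two cores in this assay, a 1.1-fold lower number (0.05 log units; within the scatter) from compound 1 to compound 3 and a 1.2-fold lower number (0.09 log units; within the scatter) from compound 2 to compound 4, 1.1-fold (0.04 log units) apart, within the scatter of two such steps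

Among these compounds, both changes therefore carry from one core to the other with no detectable difference in step size, but every step lies within the scatter, so this agreement shows only that neither change moves the number measurably on these two cores, not that either has a real effect of a fixed size that transfers.

Two cores are also a thin basis, and a third could behave differently. The compounds shown leave open what an amine, a carboxylic acid or a nitrile would give in place of the methoxy or bromo group, and whether a group other than the unsubstituted phenyl on the shared core would bring any step beyond the scatter.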